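Carboxylic Acid in Place of a Halogenated Ring

The source may hold more compounds than are shown below. What is called first, only, known or untested is meant among the compounds shown, and "the series" means these compounds.

Measured compounds:
compound 2, `O=C(O)c1cc(-c2cccc(COc3ccc4c(=O)n(CC5CC5)sc4c3)c2)ccc1Cl`: 38.4%
compound 3, `CN(C)C(=O)c1cc(-c2cccc(COc3ccc4c(=O)n(C5CCCC5)sc4c3)c2)ccc1Cl`: 54.8%

The series was examined in an assay on HEK293 cells for positive allosteric modulation of metabotropic glutamate receptor 2 (Rattus norvegicus), read by thallium flux; on this read-out higher numbers stand for larger maximal responses and lower numbers for smaller maximal responses. Compound 1, `O=C1c2ccc(OCc3cccc(-c4ccc(Cl)cc4F)c3)cc2CN1C1CCCC1`, stands nowhere on the numbers shown: in this assay compound 1 is reported as "not determined" (no result reported). Among the measured compounds shown here, of the measured members, compound 2 gives 38.4% and compound 3 gives 54.8%; these two differ in more than one place, so no single step connects them, and only the two values themselves can be taken from them.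

Compound 4, `COc1ccc(C(=O)O)cc1-c1cccc(COc2ccc3c(c2)CN(C2CCCC2)C3=O)c1`, differs from compound 1 in one place: 5-carboxy-2-methoxyphenyl in place of 4-chloro-2-fluorophenyl on an aromatic carbon. For the measured compounds named here, with no number for compound 1, no measured step can be stated, and the direction of the change in this assay cannot be read from compound 1 itself. An expectation can still be formed because compound 2 gives 38.4% while carrying a carboxylic acid on its pendant ring. On that basis compound 4 is estimated at 40% in this assay, with a range from 20% to 62%.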

Compound 4, largest response reached (reported as percent of maximum), in percent of the reference or control that the assay uses: 79.2%
Compound 4: middle estimate off by 39.2 percentage points, on the low side; measured number above the stated range.
By their numbers in this assay, from the lowest: compound 2; then compound 3; then compound 4.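

In this assay, among the compounds shown here, compound 1 has no number, so no step to compound 4 can be read. The compounds shown leave open what 5-carboxy-2-methoxyphenyl in place of 4-chloro-2-fluorophenyl does to the maximal response. No evidence at hand bears on this result.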